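A few compounds are considered here, and "the series" means these few. Any claim that something is new, unique, unknown or untested is made for them only; others in the source may bear on it.

Among the compounds with values here, in a functional assay on NCI-H460 cells (Homo sapiens) for antiproliferative activity (a higher number here means a weaker inhibitor, a lower number a stronger inhibitor), compound 2 `COc1ccc(S(=O)(=O)Oc2ccccc2NC(=O)c2ccccc2)cc1` gives 410 nM and this is the only actual number so far. Compound 1 `COc1ccc(S(=O)(=O)Oc2ccccc2NC(=O)c2ccnc3ccccc23)cc1` is reported as > 10000 nM and that is a limit of the assay, not a number.

Compound 3 `COc1ccc(S(=O)(=O)Oc2ccccc2NC(=O)c2cccnc2)cc1` keeps the rest of compound 2 but has pyridin-3-yl in place of phenyl on a carbonyl carbon, next to the amide-type nitrogen named in the comparison: pyridin-3-yl in place of phenyl on a carbonyl carbon is the full count of that swap.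

Within the data shown here, the only measured step at this carbonyl carbon is an at least 24-fold lower number from compound 1 to compound 2 (1.38 log units; beyond the scatter) and it puts phenyl in place of quinolin-4-yl. That large step is a single comparison, so it cannot show which part of the change mattered. Pyridin-3-yl shares a ring nitrogen with quinolin-4-yl, so a move toward a higher number is expected, though a much smaller one than an at least 24-fold lower number from compound 1 to compound 2 (1.38 log units; beyond the scatter) in size.

The estimated change is a 3.7-fold higher number from compound 2 to compound 3 (0.56 log units; beyond the scatter) and it would mean a weaker inhibitor. In this assay the estimate for compound 3 is 1500 nM with an expected range from 300 nM to 8000 nM around it.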

Compound 3, half-maximal inhibitory concentration: > 6000 nM
Compound 3: a limit, no number; the forecaster's own chance of this, stated with the estimate: 15%; middle value at least 4.0-fold (0.60 log units) from the limit.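

In this assay compound 3 is reported only as a limit of the assay, not as a number: the limit of > 6000 nM in this assay, at which 1 of the 3 values shown sits.

Even so, the swap of pyridin-3-yl in place of phenyl on a carbonyl carbon gives an at least 14-fold higher number from compound 2 to compound 3 (1.16 log units; beyond the scatter), which makes compound 3 the clearly weaker inhibitor. The heavy-atom count stays the same and only one ring carbon becomes a nitrogen, so this single atom change is enough for a large loss, something the earlier step could not show because quinolin-4-yl differs from phenyl in more than its ring nitrogen: the limit of > 10000 nM in this assay, at which 1 of the 3 values shown sits.

With limits on both sides, the step from compound 1 to compound 3 cannot be read, so these two compounds cannot be ranked against each other.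

As far as these compounds go, the true size of the loss for compound 3 stays open, and so does whether it depends on where the ring nitrogen sits, which pyridin-2-yl or pyridin-4-yl on the same carbonyl carbon would test. From the compounds shown here alone, it is also open whether phenyl itself is needed here, or whether cyclohexyl, or a phenyl ring carrying an amine or a carboxylic acid, would hold the activity of compound 2.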